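Cytotoxicity Outlook for a Phenethyl Ether Analogue

The compounds below may be only part of what the source reports. "The series", "measured", "known", "first", "only" and "open" are said of these compounds alone.

Compound 1 `CCC1(Cc2ccccc2)OS(=O)(=O)C=C1OCC(=O)OC`: in an ADME assay on HEL cells (Homo sapiens) for cytotoxicity, with a stated time of 3 days (on this read-out lower numbers stand for higher toxicity in this test and higher numbers for lower toxicity in this test), compound 1 gives > 400000 nM, which is a limit of the assay.
Compound 2 `CCC1(Cc2ccccc2)OS(=O)(=O)C=C1OCc1ccccc1Cl`: here compound 2 gives >= 20000 nM, again only a limit.
Compound 3 `CCC1(Cc2ccccc2)OS(=O)(=O)C=C1OCc1ccc(Cl)cc1`: compound 3 gives >= 50000 nM, also a limit.

Among the measured compounds shown here, compound 3 therefore stands at a limit, as do the other two values shown, so no compound can be ranked against another. Compound 4 `CCC1(Cc2ccccc2)OS(=O)(=O)C=C1OCCCc1ccccc1` differs from compound 3 by phenethyl in place of 4-chlorophenyl on a saturated chain carbon bound to an oxygen on an unsaturated carbon. The steps that touch this position, a step that the two limits leave unreadable from compound 1 to compound 3 and a step that the two limits leave unreadable from compound 2 to compound 3, could not be sized. No readable trend exists, so the step to compound 4 is expected to be a number no higher from compound 3 to compound 4 (the limit leaves the size open). Compound 4 is estimated at 50000 nM, between 15000 nM and 400000 nM, most likely reported as a limit again.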

Compound 4, minimum cytotoxic concentration: >= 20000 nM
Compound 4: a limit, no number; the forecaster's own chance of this, stated with the estimate: 80%; the middle value lies beyond the limit too.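

Among the compounds shown here, compound 4 gives only a limit, as do compound 1, compound 2 and compound 3, so no step to compound 4 can be read. Going by these compounds, how far these side groups separate the compounds in cytotoxicity remains open.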